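The compounds below may be only part of what the source reports. "The series", "measured", "known", "first", "only" and "open" are said of these compounds alone.

- compound 1 `CN(C[C@H]1Cc2ncccc2CN1)[C@H]1CCCc2cccnc21`: 460 nm/s
- compound 2 `NC(=O)NC/C=C/CN(C[C@H]1Cc2ncccc2CN1)[C@H]1CCCc2cccnc21`: 6 nm/s
- compound 3 `CN(C)CCCCN(C[C@H]1Cc2ncccc2CN1)[C@H]1CCCc2cccnc21`: 2 nm/s

These numbers come from an ADME assay for permeability, using PAMPA, with a stated time of 4 h, at pH 5.5; a lower number here means that the compound crosses the layer more slowly, a higher number that the compound crosses the layer faster. Among the three, compound 3 stands lowest. Compound 4 `c1cnc2c(c1)CN[C@@H](CN(CCCCN(C1COC1)C1COC1)[C@H]1CCCc3cccnc31)C2` has not yet been measured, and it changes only the end of the chain in compound 3: a group of 9 heavy atoms (6 carbon, 1 nitrogen, 2 oxygen; 2 four-membered non-aromatic rings with 1 hetero atom each) in place of a group of 3 heavy atoms (2 carbon, 1 nitrogen; no ring), on a saturated chain carbon, four bonds along the chain from an amine nitrogen.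

For the measured compounds named here, no measured step makes this exact swap. The closest case, another change at the chain end, gave a 3.0-fold lower number from compound 2 to compound 3 (0.48 log units; beyond the scatter), a modest step. Adding a chain to compound 1 gave much larger steps: a 77-fold lower number from compound 1 to compound 2 (1.88 log units; beyond the scatter) and a 230-fold lower number from compound 1 to compound 3 (2.36 log units; beyond the scatter). Compound 4 keeps its chain, so those large steps are not expected to be undone, and its number should stay far from that of compound 1.

A modest step is therefore the likeliest outcome. Its direction is only weakly supported, but an upward move seems more likely, given that compound 3 already sits at the bottom with 2 nm/s. The expected change is a 5.0-fold higher number from compound 3 to compound 4 (0.70 log units; beyond the scatter). For compound 4 the estimated value is 10 nm/s, with an expected range from 2 nm/s to 50 nm/s.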

Compound 4, apparent permeability: 62 nm/s
For compound 4 the middle estimate is 6.2-fold (0.79 log units) below the measured one; the measured number lies above the stated range.
By their numbers in this assay, from the lowest: compound 3; then compound 2; then compound 4; then compound 1.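

In this assay, for the compounds shown here, the end of the chain matters more than the earlier compounds suggested: putting the group with 2 four-membered rings in place of dimethylamino gives a 31-fold higher number from compound 3 to compound 4 (1.49 log units; beyond the scatter), whereas the only earlier change there, a 3.0-fold lower number from compound 2 to compound 3 (0.48 log units; beyond the scatter), was modest. A chain at this place therefore does not fix the number at the bottom of the series, as compound 4 keeps the chain and still regains part of the large drop seen in a 230-fold lower number from compound 1 to compound 3 (2.36 log units; beyond the scatter). Nothing measured here explains the size of this step.

From the compounds shown here alone, it remains open whether the ring oxygen atoms, the rings themselves or simply the larger group set this number. A dicyclobutylamine or a morpholine at the same place on the chain would help to separate these possibilities.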